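Moving the chlorine on the aryl arm of compound 3

The source may report more compounds than this note shows. Statements on the series, on what has been measured and on what is new or still open speak of the compounds shown alone.

Measured compounds:
Compound 1, `CCOc1cccc(/C=N/c2c(C)n(C)n(-c3ccccc3)c2=O)c1`: 295000000 nM
Compound 2, `COc1cccc(/C=N/c2c(C)n(C)n(-c3ccccc3)c2=O)c1`: 105000000 nM
Compound 3, `Cc1c(/N=C/c2ccc(Cl)cc2)c(=O)n(-c2ccccc2)n1C`: 646000000 nM

Of the compounds shown here, three sharing one core have been measured in a functional assay on P388 cells (Mus musculus) for cytotoxicity, read by MTT assay, with a stated time of 72 h; on this read-out higher numbers stand for weaker inhibition and lower numbers for stronger inhibition. Compound 3 stands at the highest number of the three, with compound 1 nearest and compound 2 furthest from it. The unmeasured compound 4, `Cc1c(/N=C/c2cccc(Cl)c2)c(=O)n(-c2ccccc2)n1C`, differs from compound 3 only in the arrangement of the same atoms: 3-chlorophenyl in place of 4-chlorophenyl on a carbon with a double bond to nitrogen.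

Among the measured compounds shown here, no measured step swaps one chlorophenyl for another. The step that bears most on it is the exchange of aryl groups on the same carbon, a 6.2-fold higher number from compound 2 to compound 3 (0.79 log units; beyond the scatter), which shows that changing the aryl group here moves the number modestly. The other step, a 2.8-fold lower number from compound 1 to compound 2 (0.45 log units; beyond the scatter), concerns the alkoxy chain and is further removed. Since the 3-substituted aryl of compound 2 sits at a lower number than the 4-substituted aryl of compound 3, a modestly lower number is expected for compound 4, though a step within the scatter is also plausible. Compound 4 is therefore estimated at 400000000 nM, with a range from 150000000 nM to 1000000000 nM, which corresponds to an expected step of a 1.6-fold lower number from compound 3 to compound 4 (0.21 log units; within the scatter).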

Compound 4, half-maximal inhibitory concentration: 550000000 nM
For compound 4 the middle estimate is 1.4-fold (0.14 log units) below the measured one, and the stated range covers the measured number.
By their numbers in this assay, from the lowest: compound 2; then compounds 1, 4 and 3 (each within the scatter of the next, the first and the last beyond it).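

In this assay, among the compounds shown here, moving the chlorine gives a 1.2-fold lower number from compound 3 to compound 4 (0.07 log units; within the scatter) and so, on a carbon with a double bond to nitrogen, 3-chlorophenyl in place of 4-chlorophenyl is a step within the scatter, which the earlier compounds, with only one chlorophenyl among them, could not show. The same new compound allows a comparison of substituents on an aromatic carbon with the arrangement on the aryl arm held the same: chloro in place of methoxy gives a 5.2-fold higher number from compound 2 to compound 4 (0.72 log units; beyond the scatter) and stays beyond the scatter, while chloro in place of ethoxy gives a 1.9-fold higher number from compound 1 to compound 4 (0.27 log units; within the scatter) and stays within it, so the gap seen earlier between compound 2 and compound 3 goes with the exchange of methoxy for chloro and not with where the chlorine sits. Nothing among the data offers a reason for any of these steps.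

The compounds shown leave open whether other groups on the aryl arm, such as an amine or a carboxylic acid, would also make so small a step when moved. Also open, on these data alone, is how a longer chain than ethoxy on the aromatic carbon would compare with the methoxy of compound 2.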